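This account rests on a few compounds, and the source may have more. Where it says the series, first, only, none or still open, it means among the compounds named here.

Compound 1 `O=C1COc2ccc(NC(=O)C3CCN(c4ccccc4Br)CC3)cc2N1` carries a 2-bromophenyl on the amine nitrogen of its six-membered ring; in an assay on HEK293 cells for displacement of a labelled ligand from transient receptor potential cation channel subfamily V member 1 (Homo sapiens) (on this read-out lower numbers stand for stronger inhibition and higher numbers for weaker inhibition), compound 1 gives 71 nM. Compound 2 `O=C1COc2ccc(NC(=O)C3CCN(c4cc(F)c(F)c(F)c4)CC3)cc2N1` has a 3,4,5-trifluorophenyl in that place, and in this assay compound 2 gives 49 nM. Going by the values given here, the change a 1.4-fold lower number from compound 1 to compound 2 (0.16 log units; within the scatter) is within the scatter, so compound 2 sits with compound 1 rather than apart from it, even though its number is the smaller of the two so far.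

Compound 3 `O=C1COc2ccc(NC(=O)C3CCN(c4ccccc4C(F)(F)F)CC3)cc2N1` differs from compound 2 in one place: 2-(trifluoromethyl)phenyl in place of 3,4,5-trifluorophenyl on an amine nitrogen in a ring. Among the compounds with values here, the only step that bears on this is the earlier swap of one aryl group for another on the same ring nitrogen, which was within the scatter. Compound 3 is therefore expected to land near compound 2 at about 60 nM, with a likely range from 20 nM to 180 nM. For compound 3 the expected step is a 1.2-fold higher number from compound 2 to compound 3 (0.09 log units; within the scatter), that is, none beyond the scatter.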

Compound 3, inhibition constant: 68 nM
The estimate for compound 3 lay 1.1-fold (0.05 log units) below the measured number; measured number inside the range.
By their numbers in this assay, from the lowest: compounds 2, 3 and 1 (each within the scatter of the next).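

Trifluoromethyl in place of bromo on an aromatic carbon gives a 1.0-fold lower number from compound 1 to compound 3 (0.02 log units; within the scatter) in this assay, the first comparison in which only that group changes while the rest of the 2-substituted phenyl stays the same. A second swap on the amine nitrogen of the six-membered ring, 2-(trifluoromethyl)phenyl in place of 3,4,5-trifluorophenyl, gives a 1.4-fold higher number from compound 2 to compound 3 (0.14 log units; within the scatter), so all three aryl groups on this nitrogen now read alike within the scatter. Nothing given here explains why these groups read alike.

On these data alone, all three aryl groups carry fluorine or bromine, so the effect of a plain phenyl, or of a methoxy group or an amine on that ring, remains open. Also open, as far as these compounds go, is whether a carboxylic acid on the ring or a benzyl group on the nitrogen would move the number beyond the scatter.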